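A few compounds are considered here, and "the series" means these few. Any claim that something is new, unique, unknown or untested is made for them only; others in the source may bear on it.

Working notes on the series.

Compound 1 `C[C@@H]1CCCN1c1c(C#N)c2c(N)ncnc2n1C` is the reference point. Within the data shown here, in an assay on isolated protein for inhibition of Leucine-rich repeat serine/threonine-protein kinase 2 variant G2019S (Homo sapiens), read by TR-FRET and LanthaScreen, with stated times of 50 min and 30 min, in the presence of a further agent that is not named here (on this read-out lower numbers stand for stronger inhibition and higher numbers for weaker inhibition), compound 1 gives 11 nM, the lowest of the three numbers measured so far. Compound 2 `C[C@@H]1CCCN1c1c(C#N)c2c(N)nc(Nc3cn(C)nc3Cl)nc2n1C` carries a (3-chloro-1-methyl-1H-pyrazol-4-yl)amino in place of hydrogen on an aromatic carbon; compound 2 gives 21 nM in this assay, and the step of a 1.9-fold higher number from compound 1 to compound 2 (0.28 log units; within the scatter) is within the scatter. Compound 3 `C[C@@H]1CCCN1c1[nH]c2ncnc(N)c2c1C#N` has hydrogen in place of methyl on an aromatic nitrogen; compound 3 gives 201 nM in this assay, and the step of an 18-fold higher number from compound 1 to compound 3 (1.26 log units; beyond the scatter) is large and beyond the scatter.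

Compound 4 `Cn1c(N)c(C#N)c2c(N)ncnc21` is not yet measured. Compared with compound 1 the change is amino in place of 2-methylpyrrolidin-1-yl on an aromatic carbon. Neither measured step touches this position: the step from compound 1 to compound 2 adds a group elsewhere and changes little, while the step from compound 1 to compound 3 shows that a small change on the shared core can cost a great deal. Among the measured compounds shown here, the only direct evidence is that compound 1, with the 2-methylpyrrolidin-1-yl in place, sits at the best number of the set. Removing that group and leaving only an amino is therefore expected to weaken inhibition in this assay, with the step of a 27-fold higher number from compound 1 to compound 4 (1.44 log units; beyond the scatter) expected to lie beyond the scatter. For compound 4 the expected value in this assay is 300 nM, with a range from 60 nM to 1500 nM.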

Compound 4, half-maximal inhibitory concentration: 8560 nM
Beside the measured number, compound 4's estimate is 29-fold (1.46 log units) below it, and the stated range ends below it.
By their numbers in this assay, from the lowest: compounds 1 and 2 (each within the scatter of the next); then compound 3; then compound 4.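

In this assay the change of 2-methylpyrrolidin-1-yl to amino on this aromatic carbon gives the largest step in the series (a 780-fold higher number from compound 1 to compound 4 (2.89 log units; beyond the scatter)), larger than the loss of methyl on the aromatic nitrogen (an 18-fold higher number from compound 1 to compound 3 (1.26 log units; beyond the scatter)) and unlike the addition that stays within the scatter (a 1.9-fold higher number from compound 1 to compound 2 (0.28 log units; within the scatter)). This position, which no earlier step touched, is therefore the one where a single change costs most among those shown, and the 2-methylpyrrolidin-1-yl cannot be reduced to an amino while keeping the number of compound 1. No measurement here bears on why the step is so large.

The exchange removes the ring, the methyl and the defined stereocentre together and brings in a hydrogen-bond donor, so the compounds shown do not tell which of these differences accounts for the step. Open as well is how a dimethylamino, an unsubstituted pyrrolidin-1-yl, a piperidin-1-yl or the other stereoisomer of the 2-methylpyrrolidin-1-yl would stand at this position, and whether any of them would match or improve on compound 1.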